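Cytotoxicity notes on three measured amides and a fourth

The source may report more compounds than this note shows. Statements on the series, on what has been measured and on what is new or still open speak of the compounds shown alone.

Measured so far:
compound 1 `CC(C)n1ncc2c(C(=O)Nc3ccncc3)cc(-c3cccs3)nc21` gives 6300 nM
compound 2 `CC(C)n1ncc2c(C(=O)Nc3ccc(F)cc3)cc(-c3ccsc3)nc21` reaches only the limit, > 200000 nM
compound 3 `CC(C)n1ncc2c(C(=O)N3CCc4cc(F)ccc43)cc(-c3cccs3)nc21` likewise reaches only the limit, > 200000 nM

For the measured compounds named here, in an ADME assay on LLC-MK2 cells (Macaca mulatta) for cytotoxicity, read by spectrophotometry and crystal violet staining, with a stated time of 4 days (a higher number here means that more compound is tolerated, a lower number that less compound is tolerated), compound 1 gives 6300 nM, the one number in the set. Compound 2 stops at a limit of the assay and gives no number, > 200000 nM. Compound 3 also stops at a limit of the assay, > 200000 nM. Going by the values given here, compound 1 therefore stands apart from the limit of > 200000 nM in this assay, at which 2 of the 3 values shown sit, as the single compound whose cytotoxicity was actually quantified. Among the compounds with values here, no two measured compounds differ in one place, so no measured step is at hand to set the size of a change.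

Compound 4 `CC(C)n1ncc2c(C(=O)Nc3cccc(C(N)=O)c3)cc(-c3cccs3)nc21` is not yet measured. Relative to compound 1 the change is 3-carbamoylphenyl in place of pyridin-4-yl on an amide-type nitrogen. Within the data shown here, with compound 1 the only quantified value and the two other amide partners at the limit, the expected direction for compound 4 in this assay is toward more compound tolerated, by a step beyond the usual scatter, though the amide partner of compound 4 is new to the set and the size is uncertain.

Compound 4 is expected at 50000 nM, with a range from 10000 nM to 200000 nM. The expected step is a 7.9-fold higher number from compound 1 to compound 4 (0.90 log units; beyond the scatter), and a reading that again ends at the limit is a real possibility.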

Compound 4, half-maximal cytotoxic concentration: 25000 nM
For compound 4 the middle estimate is 2.0-fold (0.30 log units) above the measured one, within the range that was stated.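

For the compounds shown here, the change to 3-carbamoylphenyl in place of pyridin-4-yl on an amide-type nitrogen gives a 4.0-fold higher number from compound 1 to compound 4 (0.60 log units; beyond the scatter) in this assay, the first measured step, and it shows that the amide partner alone can move this read-out beyond the scatter while the rest of the molecule stays the same. The step swaps a six-membered aromatic ring with one hetero atom for a carbon-only ring carrying a carbamoyl group, so this single pair cannot separate the loss of the ring nitrogen from the gain of the carbamoyl group. Compound 4 reads as a number and not as a limit, whereas compound 2 and compound 3 remain at a limit, and no single change links either of them to compound 4: the limit of > 200000 nM in this assay, at which 2 of the 4 values shown sit.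

An unsubstituted phenyl on the same nitrogen would separate the contribution of the ring nitrogen from that of the carbamoyl group, and a carboxylic acid or a nitrile in place of the carbamoyl group would test how specific the step is to that group. The compounds shown also leave open whether the step keeps its size when another part of the shared core changes.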